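Working notes: from compound 3 to compound 4

The compounds below may be only part of what the source reports. "The series", "measured", "known", "first", "only" and "open" are said of these compounds alone.

The three measured compounds share one core and differ at a single aromatic carbon. Compound 1 `CC(C(=O)NCc1ccc(C(F)(F)F)nc1NCc1ccc(Cl)cc1)c1ccc(NS(C)(=O)=O)c(F)c1` carries the (4-chlorobenzyl)amino group there, and in a functional assay on CHO-K1 cells for antagonist activity at transient receptor potential cation channel subfamily V member 1 (Homo sapiens), read by FLIPR (a lower number here means a stronger inhibitor, a higher number a weaker inhibitor), compound 1 gives 65.7 nM. Compound 2 `CC(C(=O)NCc1ccc(C(F)(F)F)nc1N1CCCC1)c1ccc(NS(C)(=O)=O)c(F)c1`, with pyrrolidin-1-yl in its place, gives 0.6 nM in this assay; the step is a 110-fold lower number from compound 1 to compound 2 (2.04 log units; beyond the scatter). Compound 3 `CC(C)OC1CCN(c2nc(C(F)(F)F)ccc2CNC(=O)C(C)c2ccc(NS(C)(=O)=O)c(F)c2)CC1`, with 4-isopropoxypiperidin-1-yl, gives 3 nM, a step of a 22-fold lower number from compound 1 to compound 3 (1.34 log units; beyond the scatter). Compound 3 therefore stands second highest of the three numbers: a 5.0-fold higher number from compound 2 to compound 3 (0.70 log units; beyond the scatter) separates it from its nearest neighbour, and the furthest number is that of compound 1.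

Compound 4 `CC(C(=O)NCc1ccc(C(F)(F)F)nc1N1CCC(CN(C)C)CC1)c1ccc(NS(C)(=O)=O)c(F)c1` keeps the six-membered non-aromatic ring of compound 3 and changes only the group on it: (dimethylamino)methyl in place of isopropoxy on a saturated ring carbon. Within the data shown here, no measured step exchanges one group for another on that saturated ring carbon. Among the measured compounds shown here, the only step that touches this part of the molecule is a 5.0-fold higher number from compound 2 to compound 3 (0.70 log units; beyond the scatter), which brought in the whole substituted ring in place of pyrrolidin-1-yl, and it was modest. On that basis a step of a 1.3-fold higher number from compound 3 to compound 4 (0.12 log units; within the scatter) is expected, within the scatter and with no firm direction. Compound 4 is estimated at 4 nM, with a range of 1 nM to 15 nM.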

Compound 4, inhibition constant: 2.1 nM
Estimate against measurement, compound 4: 1.9-fold (0.28 log units) above; measured number inside the range.
By their numbers in this assay, from the lowest: compound 2; then compounds 4 and 3 (each within the scatter of the next); then compound 1.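

Among these compounds, at the saturated ring carbon, three ring bonds from the ring nitrogen, the exchange of isopropoxy for (dimethylamino)methyl gives the first direct reading of a group change in this assay (a 1.4-fold lower number from compound 3 to compound 4 (0.15 log units; within the scatter)), and that step lies within the scatter, so the two groups cannot be ordered. Compound 4 also repeats the standing of compound 3 against the other two amino groups on the aromatic carbon: pyrrolidin-1-yl still gives the lower number (a 3.5-fold higher number from compound 2 to compound 4 (0.54 log units; beyond the scatter)), while (4-chlorobenzyl)amino remains far weaker (a 31-fold lower number from compound 1 to compound 4 (1.50 log units; beyond the scatter)). This holds for these two substituted rings only, and nothing available accounts for any of these steps.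

Going by these compounds, whether a carboxylic acid, a primary amine or a longer chain such as butoxy on the same ring carbon would also stay within the scatter of compound 3 remains open. Also open is whether any group on this six-membered ring can match compound 2 at 0.6 nM in this assay, since the two substituted rings shown both stay beyond the scatter of it.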